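Swapping the phenol for trifluoromethyl on the anilide ring

The compounds below may be only part of what the source reports. "The series", "measured", "known", "first", "only" and "open" are said of these compounds alone.

Measured compounds: compound 1 `CC(=O)N1c2ccccc2CCC1C(=O)Nc1ccccc1O` gives 70700 nM; compound 2 `O=C(Nc1ccccc1O)C1CCc2ccccc2N1C(=O)c1ccccc1Cl` gives 60000 nM; compound 3 `O=C(Nc1ccccc1O)C1CCc2ccccc2N1C(=O)c1ccc(Cl)cc1` gives 25100 nM.

In a functional assay on PC-3 cells (Homo sapiens) for cytotoxicity, read by sulforhodamine B assay, with a stated time of 72 h (a higher number here means a weaker inhibitor of growth, a lower number a stronger inhibitor of growth), compound 1 has the highest number of the three, with compound 2 within the scatter of it and compound 3 the furthest, as the step of a 2.8-fold lower number from compound 1 to compound 3 (0.45 log units; beyond the scatter) shows. Compound 4 `CC(=O)N1c2ccccc2CCC1C(=O)Nc1ccccc1C(F)(F)F` keeps the acetyl of compound 1 and differs only at the anilide ring: trifluoromethyl in place of hydroxy on an aromatic carbon. Among the compounds with values here, none of the measured steps touches that ring; a 1.2-fold lower number from compound 1 to compound 2 (0.07 log units; within the scatter), a 2.8-fold lower number from compound 1 to compound 3 (0.45 log units; beyond the scatter) and a 2.4-fold lower number from compound 2 to compound 3 (0.38 log units; beyond the scatter) all change the group on the carbonyl carbon, so they give no guide to this change. With no bearing data, no step beyond the scatter is expected, so compound 4 is estimated at 70000 nM (range 25000 nM to 200000 nM), a step of a 1.0-fold lower number from compound 1 to compound 4 (0.00 log units; within the scatter).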

Compound 4, concentration for 50% growth inhibition: > 80000 nM
Compound 4 ended at the assay's limit; the forecaster's own chance of this, stated with the estimate: 25%; middle value at least 1.1-fold (0.05 log units) from the limit.
By their numbers in this assay, from the lowest: compound 3; then compounds 2 and 1 (each within the scatter of the next). At a limit, above all of these: compound 4.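

Within the data shown here, this is the first change to the anilide ring, and in this assay compound 4 stands at a limit, not at a number: the limit of > 80000 nM in this assay, at which 1 of the 4 values shown sits. Trifluoromethyl in place of hydroxy gives an at least 1.1-fold higher number from compound 1 to compound 4 (0.05 log units; that floor lies within the scatter), so this swap brought no visible gain in growth inhibition, though whether any was lost cannot be told.

Still open, on these data alone, is how an amine or a methoxy group on this aromatic carbon would compare with hydroxy. Also open, as far as these compounds go, is whether trifluoromethyl would behave the same alongside the 4-chlorophenyl carbonyl of compound 3.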